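Swapping an aminoalkyl chain for an alkenyl one

A few compounds are considered here, and "the series" means these few. Any claim that something is new, unique, unknown or untested is made for them only; others in the source may bear on it.

Compound 1 `NCCCCCCOc1ccc2c(=O)c(-c3ccc(O)cc3)coc2c1`: 100 nM
Compound 2 `CCOc1ccc2c(=O)c(-c3ccc(O)cc3)coc2c1`: 80 nM
Compound 3 `O=c1c(-c2ccc(O)cc2)coc2cc(OCCCCCCCCCO)ccc12`: 700 nM

In an assay (Cricetulus griseus) for inhibition of aldehyde dehydrogenase, mitochondrial (Homo sapiens) (a higher number here means a weaker inhibitor, a lower number a stronger inhibitor), compound 1 gives 100 nM, the second highest of the three numbers. Its nearest neighbour is compound 2, a step of a 1.3-fold lower number from compound 1 to compound 2 (0.10 log units; within the scatter); its furthest is compound 3, with a 7.0-fold higher number from compound 1 to compound 3 (0.85 log units; beyond the scatter). Compound 4 `C=CCCCCOc1ccc2c(=O)c(-c3ccc(O)cc3)coc2c1` keeps the chain length of compound 1 but changes its end: vinyl in place of 2-aminoethyl on a saturated chain carbon, four bonds along the chain from an oxygen on an aromatic ring. The most relevant step is a 1.3-fold lower number from compound 1 to compound 2 (0.10 log units; within the scatter), where loss of the amine-bearing part of the chain changed little, whereas the modest weakening in an 8.8-fold higher number from compound 2 to compound 3 (0.94 log units; beyond the scatter) came with a longer chain ending in a hydroxyl. A change near compound 1 is therefore expected, a 1.1-fold lower number from compound 1 to compound 4 (0.05 log units; within the scatter). Compound 4 is estimated at 90 nM, within 40 nM to 250 nM.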

Compound 4, half-maximal inhibitory concentration: 150 nM
Compound 4: the middle estimate sits 1.7-fold (0.22 log units) below what was measured; measured number inside the range.
By their numbers in this assay, from the lowest: compounds 2, 1 and 4 (each within the scatter of the next); then compound 3.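

In this assay, vinyl in place of 2-aminoethyl gives a 1.5-fold higher number from compound 1 to compound 4 (0.18 log units; within the scatter), so at this position a chain end with no hydrogen-bond donor or acceptor is tolerated as well as the amine. Adding but-3-en-1-yl to the chain of compound 2 gives a 1.9-fold higher number from compound 2 to compound 4 (0.27 log units; within the scatter), while a 4.7-fold lower number from compound 3 to compound 4 (0.67 log units; beyond the scatter) leaves compound 3 alone among these chains in standing apart. No measurement shown accounts for these numbers.

As far as these compounds go, it remains open whether the chain length or the hydroxyl end goes with the higher number of compound 3. A longer chain ending in an amine or in vinyl would separate the two.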